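The compounds below may be only part of what the source reports. "The series", "measured", "known", "first", "only" and "open" are said of these compounds alone.

Working notes on the series.

Among the compounds with values here, in a functional assay on the whole organism for antagonist activity, with Rattus norvegicus as the target (a lower number here means that less compound is needed, a higher number that more compound is needed for the effect), compound 1 `c1ccc2c(c1)CC2CCN1CCN(c2cccc3c2OCCCO3)CC1` gives 1.25 mg/kg, the highest of the three numbers measured so far. Compound 2 `C1=C(CCN2CCN(c3cccc4c3OCCO4)CC2)c2ccccc2C1` gives 0.63 mg/kg in this assay, a value within the scatter of compound 1, and compound 3 `C1=C(CCN2CCN(c3cccc4c3OCCO4)CC2)Cc2ccccc21` gives 0.31 mg/kg, which lies beyond the scatter of compound 1. Within the data shown here, the only single-point step among the measured compounds is a 2.0-fold lower number from compound 2 to compound 3 (0.31 log units; beyond the scatter), a change in the placement of the double bond within the same ring pair.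

Compound 4 `c1ccc2c(c1)CC2CN1CCN(c2cccc3c2OCCCO3)CC1` differs from compound 1 at the linker to the ring nitrogen: a group of 8 heavy atoms (8 carbon; one four-membered non-aromatic ring of carbon only, one six-membered aromatic ring of carbon only) in place of a group of 9 heavy atoms (9 carbon; one four-membered non-aromatic ring of carbon only, one six-membered aromatic ring of carbon only), on a saturated chain carbon bound to an amine nitrogen in a ring. Among the measured compounds shown here, no measured step concerns a change of this kind, so nothing speaks for or against a shift in this assay; the change is small and the group itself is kept.

For the measured compounds named here, with no step to lean on, compound 4 is expected to stay near compound 1, the estimate being 2 mg/kg with a range from 0.6 mg/kg to 8 mg/kg. This estimate means an expected step of a 1.6-fold higher number from compound 1 to compound 4 (0.20 log units; within the scatter), which would sit within the scatter.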

Compound 4, minimum effective dose: 0.63 mg/kg
Beside the measured number, compound 4's estimate is 3.2-fold (0.50 log units) above it; low and high end bracket the measured number.
By their numbers in this assay, from the lowest: compound 3; then compounds 2, 4 and 1 (each within the scatter of the next).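

Within the data shown here, the step of a 2.0-fold lower number from compound 1 to compound 4 (0.30 log units; within the scatter) is the first reading at this position in this assay, on a saturated chain carbon bound to an amine nitrogen in a ring. It does not separate the group of 8 heavy atoms from the group of 9 heavy atoms, so this assay tolerates the change, with both the four-membered non-aromatic ring and the six-membered aromatic ring kept. Nothing on hand accounts for this result.

The compounds shown leave open whether a longer chain at this place, or an amine carried on the chain, would stay within the scatter of compound 1 or move clearly away from it. Also open, going by these compounds, is whether the same change would read alike on the core of compound 2 and compound 3.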